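A few compounds are considered here, and "the series" means these few. Any claim that something is new, unique, unknown or untested is made for them only; others in the source may bear on it.

Three compounds sharing one core have been measured in an assay on HEK293 cells for negative allosteric modulation of metabotropic glutamate receptor 5 (Homo sapiens), read by FLIPR, with a stated time of 1 h; on this read-out lower numbers stand for stronger inhibition and higher numbers for weaker inhibition:
Compound 1 `CC(C)CN1CCc2nc(C#Cc3ccccc3)sc2C1` gives 650 nM.
Compound 2 `C(#Cc1nc2c(s1)CN(C1CCCCC1)CC2)c1ccccc1` gives only a limit of the assay, > 10000 nM.
Compound 3 `CC1CC(C(=O)N2CCc3nc(C#Cc4ccccc4)sc3C2)C1` likewise gives only a limit of the assay, > 10000 nM.

Compound 3 therefore stands at the weak end of what this assay can report: its value is not a number but the point past which the assay stops counting, and compound 2 sits at the same place (the limit of > 10000 nM in this assay, at which 2 of the 3 values shown sit). The next compound, compound 4 `O=C(CC1CCOCC1)N1CCc2nc(C#Cc3ccccc3)sc2C1`, keeps the carbonyl on the ring nitrogen and changes only what hangs from it: (oxan-4-yl)methyl in place of 3-methylcyclobutyl on a carbonyl carbon. Going by the values given here, two measured steps touch this part of the molecule. Replacing the isobutyl of compound 1 with the (3-methylcyclobutyl)carbonyl of compound 3 gave an at least 15-fold higher number from compound 1 to compound 3 (1.18 log units; beyond the scatter), and replacing it with cyclohexyl gave an at least 15-fold higher number from compound 1 to compound 2 (1.18 log units; beyond the scatter). The step between the two weak compounds, a step that the two limits leave unreadable from compound 2 to compound 3, cannot be sized. Among the compounds with values here, compound 4 carries the same kind of carbonyl attachment that already took compound 3 out of the measurable range, and no measured step shows such an attachment recovering potency. The expected step is a step that the limit leaves unreadable from compound 3 to compound 4, meaning no change beyond the scatter. Compound 4 is estimated at 15000 nM, between 5000 nM and 50000 nM, most likely reported again as a limit.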

Compound 4, half-maximal inhibitory concentration: > 10000 nM
Compound 4 was reported as a limit; the forecaster's own chance of this, stated with the estimate: 80%; the middle value lies beyond the limit too.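

Compound 3 and compound 4 both stop at the assay's limit rather than giving numbers, so the step between them cannot be read: the limit of > 10000 nM in this assay, at which 3 of the 4 values shown sit.

The compounds shown leave open how far apart compound 3 and compound 4 truly lie, and whether any group on this carbonyl carbon can give a measurable value in this assay.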